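The source may hold more compounds than are shown below. What is called first, only, known or untested is meant among the compounds shown, and "the series" means these compounds.

The series rests on a shared core carrying an ethyl-substituted pyrazole and, at the other end, a saturated nitrogen ring closed by an amide. Compound 1 `CCC(=O)N1CC[C@H](Nc2ncnc3c2nc(-c2cnn(CC)c2C)n3C)C1` links that ring to the core through an amine and carries a propanoyl group on the ring nitrogen; in an ADME assay (Rattus norvegicus, strain Wistar Han) for metabolic stability (a higher number here means that the compound lasts longer, a lower number that the compound disappears faster), compound 1 gives 0.4 h. Compound 2 `CCn1ncc(-c2nc3c(O[C@H]4CCN(C(=O)C5CC5)C4)ncnc3n2C)c1C` instead links the ring to the core through an oxygen and carries a cyclopropylcarbonyl group; in this assay compound 2 gives 0.4 h. The two values stand level at the digits shown, so no order between them can be read.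

Compound 3 `CCn1ncc(-c2nc3c(O[C@H]4CCN(C(=O)C5CCOCC5)C4)ncnc3n2C)c1C` differs from compound 2 in one place: oxan-4-yl in place of cyclopropyl on a carbonyl carbon. Whether a cyclopropylcarbonyl or an (oxan-4-yl)carbonyl sits on the ring nitrogen is not tested elsewhere in the set, so the expectation leans on the two short half-lives already seen. Compound 3 is expected to behave much as compound 2, with the step of a 1.3-fold higher number from compound 2 to compound 3 (0.10 log units; within the scatter) lying within the scatter. The half-life of compound 3 is therefore estimated at 0.5 h, between 0.2 h and 1.2 h.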

Compound 3, half-life: 0.8 h
Compound 3: middle estimate off by 1.6-fold (0.20 log units), on the low side; low and high end bracket the measured number.
By their numbers in this assay, from the lowest: compounds 1, 2 and 3 (each within the scatter of the next).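

Among the compounds shown here, with cyclopropyl replaced by oxan-4-yl on a carbonyl carbon whose other neighbour is an amide-type nitrogen in a ring, the series gains its only comparison that differs in one place: in this assay, the change gives a 2.0-fold higher number from compound 2 to compound 3 (0.30 log units; within the scatter) and so does not separate the two groups. This shows that the three-membered carbon ring can give way to a six-membered ring with one oxygen and one hydrogen-bond acceptor without a half-life difference beyond the usual scatter of repeated measurements. Nothing measured here explains this outcome.

Compound 1 and compound 2 differ in both the link to the core and the acyl group on the ring nitrogen, so the contribution of each of these two differences remains unresolved. As far as these compounds go, it also remains open how this half-life would respond if a group of another kind, such as a piperidin-4-yl amine, a carboxylic acid or a longer open methoxyethyl chain, stood on the same carbonyl carbon.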